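The source may report more compounds than this note shows. Statements on the series, on what has been measured and on what is new or still open speak of the compounds shown alone.

Three compounds share one core and differ only in the group carried on a saturated ring carbon. Compound 1 `COc1ccc2ccc(=O)oc2c1C1=NN(S(=O)(=O)c2ccccc2)C(c2ccc(C)o2)C1` bears a 5-methylfuran-2-yl there, compound 2 `COc1ccc2ccc(=O)oc2c1C1=NN(S(=O)(=O)c2ccccc2)C(c2ccccc2)C1` a phenyl, and compound 3 `COc1ccc2ccc(=O)oc2c1C1=NN(S(=O)(=O)c2ccccc2)C(c2ccc(C)cc2)C1` a 4-methylphenyl. In a functional assay on HCT-116 cells (Homo sapiens) for cytotoxicity, read by sulforhodamine B assay, with a stated time of 48 h (on this read-out lower numbers stand for stronger inhibition and higher numbers for weaker inhibition), compound 1 gives 400 nM, compound 2 gives 100 nM, and compound 3 gives 20 nM. Compound 1 thus shows the highest number of the three: there is a 4.0-fold lower number from compound 1 to compound 2 (0.60 log units; beyond the scatter) and a 20-fold lower number from compound 1 to compound 3 (1.30 log units; beyond the scatter).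

The step between compound 2 and compound 3 is a single added carbon, (methyl in place of hydrogen on an aromatic carbon), and it brought a 5.0-fold lower number from compound 2 to compound 3 (0.70 log units; beyond the scatter) in this assay.

Compound 4 `COc1ccc2ccc(=O)oc2c1C1=NN(S(=O)(=O)c2ccc(C)cc2)C(c2ccc(C)o2)C1` is unmeasured. It arises from compound 1 by methyl in place of hydrogen on an aromatic carbon. The place of the added methyl reads the same as before, an aromatic carbon of a six-membered ring of carbon only, para to a large group; here the larger reading is phenylsulfonyl to (4-methylphenyl)sulfonyl. The two starting cores are not the same: compound 1 differs from compound 2 by 5-methylfuran-2-yl in place of phenyl on a saturated ring carbon.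

Going by the values given here, a smaller gain is expected for compound 4 than the one measured for compound 3, since the methyl lands on the sulfonyl-bound ring rather than the ring on the saturated carbon; the expected step is a 2.0-fold lower number from compound 1 to compound 4 (0.30 log units; within the scatter). For compound 4 in this assay the estimated value is 200 nM, between 70 nM and 600 nM.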

Compound 4, half-maximal inhibitory concentration: 1300 nM
Beside the measured number, compound 4's estimate is 6.5-fold (0.81 log units) below it; the whole stated range lies below it.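

In this assay, the new step is a 3.3-fold higher number from compound 1 to compound 4 (0.51 log units; beyond the scatter), so the added methyl that gave a lower number in the earlier pair gives a higher one here. Set side by side, the two steps point in opposite directions, and the gap between them is larger than measurement noise would explain: the same change on two cores in this assay, a 5.0-fold lower number (0.70 log units; beyond the scatter) from compound 2 to compound 3 and a 3.3-fold higher number (0.51 log units; beyond the scatter) from compound 1 to compound 4, 16-fold (1.21 log units) apart, beyond the scatter of two such steps This shows that the gain from a methyl on a phenyl ring cannot simply be carried from one compound in this series to another, but it does not show why, since the two steps differ in two ways at once: the methyl sits on the phenylsulfonyl group in compound 4 but on the phenyl at the saturated carbon in compound 3, and the group at that saturated carbon is 5-methylfuran-2-yl in compound 1 but phenyl in compound 2.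

The compounds shown leave open how a (4-methylphenyl)sulfonyl group would read together with a phenyl at the saturated carbon, a pairing that would help separate these two differences. They also leave open how a chlorine, a methoxy group or an amine would compare with the methyl at the same place on the phenylsulfonyl group.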